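The compounds below may be only part of what the source reports. "The series", "measured", "known", "first", "only" and "open" are said of these compounds alone.

Measured so far:
Compound 1, `COC(=O)/C(=C/Cn1c(-c2ccccc2)ncc(NC(=O)OCc2ccccc2)c1=O)COC(=O)c1ccc([N+](=O)[O-])cc1`, in a functional assay on cells (Neuronal cell line, Homo sapiens) for inhibition (on this read-out lower numbers stand for stronger inhibition and higher numbers for weaker inhibition), gives 1.75 ug/mL.
Compound 2, `COC(=O)/C(=C/Cn1c(-c2ccccc2)ncc(NC(=O)OCc2ccccc2)c1=O)COC(C)=O`, in this assay gives 0.92 ug/mL.

Compound 2 sits beside compound 1 on the numbers shown, the two within the usual scatter of each other. Compound 3, `COC(=O)/C(=C/Cn1c(-c2ccccc2)ncc(NC(=O)OCc2ccccc2)c1=O)CO`, differs from compound 2 in one place: hydrogen in place of acetyl on an oxygen on a saturated carbon. Within the data shown here, the only measured step that touches this part of the molecule, a 1.9-fold lower number from compound 1 to compound 2 (0.28 log units; within the scatter), swapped one acyl group for another and stayed within the scatter. Trimming the acetyl away is therefore expected to leave the number roughly unchanged, a step of a 1.1-fold higher number from compound 2 to compound 3 (0.04 log units; within the scatter). For compound 3 in this assay the estimate is 1 ug/mL, between 0.4 ug/mL and 2.5 ug/mL.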

Compound 3, half-maximal inhibitory concentration: 0.95 ug/mL
For compound 3 the middle estimate is 1.1-fold (0.02 log units) above the measured one, and the stated range covers the measured number.
By their numbers in this assay, from the lowest: compounds 2, 3 and 1 (each within the scatter of the next).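

In this assay taking the acyl group off this oxygen entirely, leaving a hydroxy, gives a 1.0-fold higher number from compound 2 to compound 3 (0.01 log units; within the scatter) and a 1.8-fold lower number from compound 1 to compound 3 (0.27 log units; within the scatter) and so stays within the scatter from either acylated form. Among these compounds, then, neither acetyl nor (4-nitrophenyl)carbonyl on this oxygen is needed to reach numbers of this size. Nothing available here offers an explanation for this. Still open, as far as these compounds go, is whether the oxygen itself matters. An amine or a methyl ether in place of the hydroxy could give a different number, as could a longer chain.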